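The compounds below may be only part of what the source reports. "The series", "measured", "known", "first", "only" and "open" are said of these compounds alone.

Measured so far:
- compound 1, `ClCc1cccc(Cn2cnc3c(Cl)nc(Cl)nc32)c1`: 4360 nM
- compound 2, `Nc1nc(Cl)c2ncn(Cc3ccccc3CCl)c2n1`: 61700 nM

Both compounds were tested in a functional assay on HOP-62 cells (Homo sapiens) for cytotoxicity, read by sulforhodamine B assay, with a stated time of 48 h; on this read-out lower numbers stand for stronger inhibition of growth and higher numbers for weaker inhibition of growth. Compound 2 has the highest of the two numbers, so it is the weaker growth inhibitor of the pair; its nearest neighbour is compound 1, whose number is lower by a margin well beyond the usual scatter of repeated measurements. For the measured compounds named here, the two compounds differ in more than one place, so no single structural step connects their values.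

Compound 3, `ClCc1ccccc1Cn1cnc2c(Cl)nc(Cl)nc21`, is the unmeasured compound. Set against compound 2, the change is chloro in place of amino on an aromatic carbon. This puts a chloro group on the six-membered ring part of the shared core where compound 2 carries an amino group, which makes compound 3 resemble compound 1 in that part of the structure.

In this assay a step toward lower numbers is expected, because compound 1 gives 4360 nM with the same chloro group at that position, though the two compounds also differ elsewhere. The expected step from compound 2 to compound 3 is a 6.9-fold lower number from compound 2 to compound 3 (0.84 log units; beyond the scatter). Compound 3 is estimated at 9000 nM, likely falling between 3000 nM and 30000 nM.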

Compound 3, concentration for total growth inhibition: 3630 nM
The estimate for compound 3 lay 2.5-fold (0.39 log units) above the measured number; low and high end bracket the measured number.
By their numbers in this assay, from the lowest: compounds 3 and 1 (each within the scatter of the next); then compound 2.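

In this assay, this position on the six-membered aromatic ring, between two ring nitrogen atoms, proves highly sensitive to what it carries: chloro in place of amino gives a 17-fold lower number from compound 2 to compound 3 (1.23 log units; beyond the scatter). The earlier comparison could not show this, since compound 1 and compound 2 differ in more than one place, whereas here a large change in growth inhibition follows the exchange of one heavy atom, with the hydrogen-bond donor and acceptor counted for amino gone and none counted for chloro. No available measurement explains why the number falls with this change.

This single pair cannot show whether chloro itself matters most or whether the loss of amino does, and a methoxy group, a methylamino group or a plain hydrogen at the same position could help separate the two. It also leaves open whether the step would keep its size with the chloromethyl group placed on the benzene ring as in compound 1.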